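Swapping chloro for fluoro on the thiourea aryl ring

The source may hold more compounds than are shown below. What is called first, only, known or untested is meant among the compounds shown, and "the series" means these compounds.

Of the compounds shown here, three sharing one core have been measured in a functional assay on HeLa cells (Homo sapiens) for antiproliferative activity, with a stated time of 24 h; on this read-out higher numbers stand for weaker inhibition and lower numbers for stronger inhibition. Compound 1 `NC(=O)c1c(NC(=O)c2ccccc2Cl)sc2c1CCN(C(=S)Nc1ccccc1F)C2` gives 28700 nM in this assay, compound 2 `NC(=O)c1c(NC(=O)c2ccccc2F)sc2c1CCN(C(=S)Nc1ccccc1Cl)C2` gives 19400 nM and compound 3 `NC(=O)c1c(NC(=O)c2ccccc2C(F)(F)F)sc2c1CCN(C(=S)Nc1ccccc1Cl)C2` gives 46900 nM, the highest of the three numbers; compound 1 lies within the scatter of it, compound 2 beyond. Going by the values given here, the single change that can be read as one step is a 2.4-fold higher number from compound 2 to compound 3 (0.38 log units; beyond the scatter). Compound 4 `NC(=O)c1c(NC(=O)c2ccccc2C(F)(F)F)sc2c1CCN(C(=S)Nc1ccccc1F)C2` differs from compound 3 by fluoro in place of chloro on an aromatic carbon. Among the compounds with values here, no measured step covers this change at this position: compound 1 and compound 2 carry the two halogens swapped between the two aryl rings and so differ in two places, and their values alone cannot be attributed to either ring. The author therefore expects no step beyond the scatter from compound 3 to compound 4, a 1.2-fold lower number from compound 3 to compound 4 (0.07 log units; within the scatter). Compound 4 is estimated at 40000 nM in this assay, with a range from 18000 nM to 90000 nM.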

Compound 4, half-maximal inhibitory concentration: > 50000 nM
Compound 4: a limit, no number; the forecaster's own chance of this, stated with the estimate: 15%; at least 1.2-fold (0.09 log units) between middle value and limit.
By their numbers in this assay, from the lowest: compounds 2, 1 and 3 (each within the scatter of the next, the first and the last beyond it). At a limit, above all of these: compound 4.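

In this assay compound 4 gives no number, only a limit of the assay: the limit of > 50000 nM in this assay, at which 1 of the 4 values shown sits. Fluoro in place of chloro on this aromatic carbon, read alone for the first time, gives an at least 1.0-fold higher number from compound 3 to compound 4 (0.02 log units; that floor lies within the scatter), so the change brings no lower number here, although that floor lies within the scatter and shows no real loss either. Trifluoromethyl in place of chloro, with the 2-fluorophenyl held fixed, gives an at least 1.7-fold higher number from compound 1 to compound 4 (0.24 log units; that floor lies within the scatter), again a floor within the scatter, so it cannot yet be set beside a 2.4-fold higher number from compound 2 to compound 3 (0.38 log units; beyond the scatter).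

From the compounds shown here alone, how far compound 4 lies beyond its limit stays open, and with it the true size of both new steps. Going by these compounds, whether a methoxy, an amine or a carboxylic acid on this aromatic carbon would give a lower number also stays open.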